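The compounds below may be only part of what the source reports. "The series", "measured", "known", "first", "only" and "open" are said of these compounds alone.

Working notes on the series. Three compounds have numbers in a functional assay on MCF7 cells (Homo sapiens) for antiproliferative activity, read by sulforhodamine B assay, with a stated time of 48 h; a lower number here means a stronger inhibitor, a higher number a weaker inhibitor. Compound 1 `O=C1NCCN1c1ccc(S(=O)(=O)Nc2cccc(Br)c2)cc1` gives 100 nM in this assay, compound 2 `COc1ccccc1NS(=O)(=O)c1ccc(N2CCNC2=O)cc1` gives 770 nM, and compound 3 `Cc1cccc(NS(=O)(=O)c2ccc(N3CCNC3=O)cc2)c1` gives 190 nM. Compound 1 has the lowest number of the three: the nearest is compound 3, with a 1.9-fold higher number from compound 1 to compound 3 (0.28 log units; within the scatter), and the furthest is compound 2, with a 7.7-fold higher number from compound 1 to compound 2 (0.89 log units; beyond the scatter).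

Compound 4 `Cc1ccc(NS(=O)(=O)c2ccc(N3CCNC3=O)cc2)cc1` has not been measured in this assay. Relative to compound 1 the change is 4-methylphenyl in place of 3-bromophenyl on a sulfonamide nitrogen.

For the measured compounds named here, two measured steps bear on this. The exchange of bromo for methyl on the aromatic carbon, a 1.9-fold higher number from compound 1 to compound 3 (0.28 log units; within the scatter), stayed within the scatter, so swapping these two groups on the phenyl ring carried by the sulfonamide nitrogen cost little. Going by the values given here, the step of a 4.1-fold lower number from compound 2 to compound 3 (0.61 log units; beyond the scatter) shows that the choice of substituent on that phenyl ring can matter, but no compound with a 4-methylphenyl has a number yet. The expectation in this assay is therefore a small step, if any, from compound 1 to compound 4, most likely toward a somewhat higher number, and compound 4 is estimated at 220 nM, within 80 nM to 650 nM. That estimate means a step of a 2.2-fold higher number from compound 1 to compound 4 (0.34 log units; beyond the scatter).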

Compound 4, half-maximal inhibitory concentration: 610 nM
The estimate for compound 4 lay 2.8-fold (0.44 log units) below the measured number, and the stated range covers the measured number.
By their numbers in this assay, from the lowest: compounds 1 and 3 (each within the scatter of the next); then compounds 4 and 2 (each within the scatter of the next).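

In this assay, for the compounds shown here, moving only the methyl, as 4-methylphenyl in place of 3-methylphenyl on the sulfonamide nitrogen, gives a 3.2-fold higher number from compound 3 to compound 4 (0.51 log units; beyond the scatter), so for this substituent its place on the phenyl ring matters as well as its identity, which the earlier compounds could not show. The change from the 3-bromophenyl gives a 6.1-fold higher number from compound 1 to compound 4 (0.79 log units; beyond the scatter), while a 1.3-fold lower number from compound 2 to compound 4 (0.10 log units; within the scatter) places the 4-methylphenyl and 2-methoxyphenyl compounds within the scatter of each other, leaving the two 3-substituted compounds, compound 1 and compound 3, apart from both in this small set. Nothing at hand gives a reason for the gap between the 3-methylphenyl and 4-methylphenyl compounds.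

Still open, going by these compounds, is whether the same gap appears with another pair, such as 3-bromophenyl against 4-bromophenyl, or whether it belongs to the methyl alone. Also open, on these data alone, is how a 3-methoxyphenyl, or a phenyl ring carrying an amine or a carboxylic acid at the 3-position, would stand in this assay against compound 1 and compound 3.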